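Swapping a Ring for a Branch on a Shared Core

A few compounds are considered here, and "the series" means these few. Any claim that something is new, unique, unknown or untested is made for them only; others in the source may bear on it.

Three compounds share one core and differ at two places: the carbon group on a saturated ring carbon, and a tail elsewhere in the molecule. Compound 1, `CC1(C2CCCC2)Cc2cc(OCCOc3ccc(-c4nn[nH]n4)cc3)c(Cl)c(Cl)c2C1=O`, carries a cyclopentyl and one tail; in an assay on isolated protein for binding affinity to metabotropic glutamate receptor 2 (Homo sapiens) (a higher number here means that more compound is needed for the effect, a lower number that less compound is needed), compound 1 gives 276 nM. Compound 2, `CC(C)C1Cc2cc(OCc3ccc(-c4nn[nH]n4)cc3)c(Cl)c(Cl)c2C1=O`, carries an isopropyl with a second tail; in this assay compound 2 gives 195 nM. Compound 3, `O=C1c2c(cc(OCc3cccc(CSc4ccncc4)c3)c(Cl)c2Cl)CC1C1CCCC1`, carries a cyclopentyl and a third tail; in this assay compound 3 gives 165 nM. That is the lowest of the three numbers, yet the gaps to compound 2 and to compound 1 both lie within the scatter of repeated measurements, so no ordering among the three can be claimed.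

Compound 4, `CC(C)C1Cc2cc(OCc3cccc(CSc4ccncc4)c3)c(Cl)c(Cl)c2C1=O`, keeps the tail of compound 3 and changes only one place: isopropyl in place of cyclopentyl on a saturated ring carbon. Among the measured compounds shown here, no pair of measured compounds isolates this change. Compounds 1 and 2 differ in the same way but also in their tails, so their numbers cannot be read as the effect of the swap alone. The expectation for compound 4 is therefore a step of no more than the scatter, a 1.2-fold higher number from compound 3 to compound 4 (0.08 log units; within the scatter), with no firm direction. Compound 4 is estimated at 200 nM, expected between 80 nM and 500 nM.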

Compound 4, half-maximal effective concentration: 839 nM
Compound 4: the middle estimate sits 4.2-fold (0.62 log units) below what was measured; the measured number lies above the stated range.
By their numbers in this assay, from the lowest: compounds 3, 2 and 1 (each within the scatter of the next); then compound 4.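

In this assay, with the tail of compound 3 kept and isopropyl put in place of cyclopentyl on a saturated ring carbon, the result is a 5.1-fold higher number from compound 3 to compound 4 (0.71 log units; beyond the scatter) and this step lies beyond the scatter. Among the compounds shown here, this is the first clean reading of the position: the group on this carbon does matter, and with this tail, more compound is needed when the five-membered ring of carbon gives way to the open branch. The earlier compounds could not show this, since their numbers lay within the scatter of one another and their differences on this carbon came together with different tails, while nothing available here accounts for the size of the step.

From the compounds shown here alone, with only these two groups compared on this tail, it stays open whether the ring itself counts or only the number of carbons, a question that a cyclohexyl, a cyclopropyl or a straight butyl chain on the same carbon would help to settle. Going by these compounds, it also stays open whether the same swap would give a step of similar size with the tails of compound 1 and compound 2.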